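Shifting the Fluorine of Compound 3

The source may report more compounds than this note shows. Statements on the series, on what has been measured and on what is new or still open speak of the compounds shown alone.

Of the compounds shown here, three built on one shared core have been measured in a functional assay on IMR-32 cells (Homo sapiens) for inhibition, read by sulforhodamine B assay, with a stated time of 48 h; on this read-out higher numbers stand for weaker inhibition of growth and lower numbers for stronger inhibition of growth. Compound 1 `O=C(CCN1C(=O)CSc2ccccc21)N1CCN(c2ccc([N+](=O)[O-])cc2)CC1` gives 340 nM in this assay. Compound 2 `CC(C)(C)OC(=O)N1CCN(C(=O)CCN2C(=O)CSc3ccccc32)CC1` reaches only the limit of this assay, > 100000 nM, so no number is known for it. Compound 3 `O=C(CCN1C(=O)CSc2ccccc21)N1CCN(c2ccc(F)cc2)CC1` gives 10000 nM. Of the two real numbers, compound 3 stands highest, and its nearest neighbour is compound 1. The change of fluoro in place of nitro on an aromatic carbon brought a 29-fold higher number from compound 1 to compound 3 (1.47 log units; beyond the scatter). Exchanging the whole aryl group for tert-butoxycarbonyl brought an at least 290-fold higher number from compound 1 to compound 2 (2.46 log units; beyond the scatter), and putting 4-fluorophenyl back in its place brought an at least 10-fold lower number from compound 2 to compound 3 (1.00 log units; beyond the scatter).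

Compound 4 `O=C(CCN1C(=O)CSc2ccccc21)N1CCN(c2ccccc2F)CC1` differs from compound 3 only in where the fluorine sits: 2-fluorophenyl in place of 4-fluorophenyl on an amine nitrogen in a ring. Within the data shown here, none of the measured steps moves a substituent around the same aromatic ring; each of them either exchanges the group on the ring nitrogen or changes the substituent itself. They give no basis for expecting a step beyond the scatter in this assay from compound 3 to compound 4, in either direction. Compound 4 is therefore estimated at 12000 nM, within 3000 nM to 50000 nM, which means an expected step of a 1.2-fold higher number from compound 3 to compound 4 (0.08 log units; within the scatter).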

Compound 4, concentration for 50% growth inhibition: > 100000 nM
Compound 4: only a limit was reported; the forecaster's own chance of this, stated with the estimate: 10%; middle value at least 8.3-fold (0.92 log units) away from the limit.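

Moving the fluorine alone, with the same atoms joined differently, matters in this assay: 2-fluorophenyl in place of 4-fluorophenyl on the amine nitrogen of the ring brought an at least 10-fold higher number from compound 3 to compound 4 (1.00 log units; beyond the scatter), something the earlier steps could not show, since none of them moved a substituent around the aromatic ring. Compound 4 gives > 100000 nM, which is a limit of the assay and not a number. Set against the 4-nitrophenyl group, the 2-fluorophenyl group brought an at least 290-fold higher number from compound 1 to compound 4 (2.46 log units; beyond the scatter), while the step between compound 2 and compound 4 cannot be read because both values are limits: the limit of > 100000 nM in this assay, at which 2 of the 4 values shown sit.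

On these data alone, the true size of the loss for compound 4 remains open, and so does the question of whether it follows from the place of the fluorine alone or would appear with other substituents in that place. An unsubstituted phenyl group, or a chlorine atom or a methoxy group in the place of the fluorine of the 2-fluorophenyl group, would help to separate these two readings.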